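The source may hold more compounds than are shown below. What is called first, only, known or untested is meant among the compounds shown, and "the series" means these compounds.

Series so far, read in a functional assay on RL cells (Homo sapiens) for antiproliferative activity, read by MTT assay, with a stated time of 72 h; a lower number here means a stronger inhibitor, a higher number a weaker inhibitor
- compound 1 `COc1ccc2sc(/C=C\c3cc(OC)c(OC)c(OC)c3)cc2c1` gives "not determined" (no result reported)
- compound 2 `COc1cc(/C=C\c2cc3cc(O)ccc3s2)cc(OC)c1OC` gives "not determined" (no result reported)
- compound 3 `COc1ccsc1/C=C\c1cc(OC)c(OC)c(OC)c1` gives > 1000 nM

Compound 3 stands at > 1000 nM in this assay and this is a limit of the assay, not a number. For the measured compounds named here, no other compound has a result, so compound 3 cannot be ranked against a measured neighbour.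

Compound 4 `COc1csc(/C=C\c2cc(OC)c(OC)c(OC)c2)c1` is the next compound to be read. The change from compound 3 is 4-methoxythiophen-2-yl in place of 3-methoxythiophen-2-yl on a double-bonded chain carbon bound to a double-bonded chain carbon and it puts 4-methoxythiophen-2-yl in place of 3-methoxythiophen-2-yl on a double-bonded chain carbon bound to a double-bonded chain carbon. The two compounds have the same atoms, joined differently.

Going by the values given here, no measured step speaks to this change. The expectation therefore rests on compound 3 alone, whose > 1000 nM is only a limit. In this assay no step beyond the usual scatter is expected, in either direction, and another result reported only as a limit would not be a surprise. The expected size of the move is a step of a number no higher from compound 3 to compound 4 (the limit leaves the size open) and it is a rough estimate. For compound 4 the estimated half-maximal inhibitory concentration is 1000 nM with an expected range from 150 nM to 5000 nM in this read-out.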

Compound 4, half-maximal inhibitory concentration: 11 nM
Compound 4: the middle estimate sits 91-fold (1.96 log units) above what was measured, and the stated range ends above it.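

For the compounds shown here, with 4-methoxythiophen-2-yl in place of 3-methoxythiophen-2-yl on a double-bonded chain carbon bound to a double-bonded chain carbon, this assay shows an at least 90-fold lower number from compound 3 to compound 4 (1.95 log units; beyond the scatter), the first readable step and a large one, beyond the scatter. The two compounds have the same atoms, joined differently, and the leaving and entering groups match in their counts of heavy atoms, hydrogen-bond donors and acceptors, so at this place the way the methoxythiophene is joined is enough to separate a result with a number from one without. For compound 3 the value > 1000 nM is a limit of the assay, not a number, so the size of the step stays open on one side: the limit of > 1000 nM in this assay, at which 1 of the 4 values shown sits.

Open, as far as these compounds go, is how an amine or a longer ether chain in place of the methoxy of 4-methoxythiophen-2-yl would read in this assay. Open too, from the compounds shown here alone, is whether the step carries over to a different shared core, as compound 1 and compound 2 give no result to compare with.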